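A few compounds are considered here, and "the series" means these few. Any claim that something is new, unique, unknown or untested is made for them only; others in the source may bear on it.

Measured compounds:
compound 1, `CCOc1nc(N)nc2[nH]cnc12`: > 1000000 nM
compound 2, `CCCCOc1nc(N)nc2[nH]cnc12`: 493000 nM
compound 3, `CCCCCCOc1[nH]c(N)nc2ncnc1-2`: 554000 nM

In an assay on HT-29 cells for inhibition of Methylated-DNA--protein-cysteine methyltransferase (Homo sapiens) (a lower number here means a stronger inhibitor, a higher number a weaker inhibitor), compound 1 gives > 1000000 nM, which is a limit of the assay and not a number. Compound 2 gives 493000 nM in this assay, and compound 3 gives 554000 nM; these two values lie within the scatter of each other, so nothing separates them. Among the measured compounds shown here, the one step that can be read, an at least 2.0-fold lower number from compound 1 to compound 2 (0.30 log units; that floor lies within the scatter), rests on the limit of > 1000000 nM in this assay, at which 1 of the 3 values shown sits, and therefore only sets a floor.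

Compound 4, `C#CCOc1nc(N)nc2[nH]cnc12`, differs from compound 1 as ethynyl in place of methyl on a saturated chain carbon bound to an oxygen on an aromatic ring. The change bears on the same chain as the measured step from compound 1 to compound 2, but in a different way: the ethyl added there lengthens the chain, whereas here a methyl leaves and an ethynyl enters. For the measured compounds named here, no measured pair shows this exchange. Because compound 2 reaches only 493000 nM with a longer chain, the expectation for compound 4 is a weak number of the same order, and the expected step is an at least 1.4-fold lower number from compound 1 to compound 4 (0.15 log units; that floor lies within the scatter). Compound 4 is estimated at 700000 nM, between 250000 nM and 2000000 nM.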

Compound 4, half-maximal inhibitory concentration: 20000 nM
Compound 4: middle estimate off by 35-fold (1.54 log units), on the high side, and the stated range ends above it.
By their numbers in this assay, from the lowest: compound 4; then compounds 2 and 3 (each within the scatter of the next). At a limit, above all of these: compound 1.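

Until now, the only change shown at this place, on a saturated chain carbon bound to an oxygen on an aromatic ring, was a longer saturated chain, and its effect could not be separated from the scatter. In this assay ethynyl in place of propyl gives a 25-fold lower number from compound 2 to compound 4 (1.39 log units; beyond the scatter) and so shows that what sits on this carbon can matter much more than that earlier step revealed. Compound 1 gives only a limit of the assay, so an at least 50-fold lower number from compound 1 to compound 4 (1.69 log units; beyond the scatter) is a floor and not a measured size: the limit of > 1000000 nM in this assay, at which 1 of the 4 values shown sits.

On these data alone, how an allyl group, with a double bond in place of the triple bond, would read here remains open, as does a longer chain ending in ethynyl. The compounds shown also do not tell why the ethynyl group makes so large a difference.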